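Removing One Methoxy Group from Compound 2

A few compounds are considered here, and "the series" means these few. Any claim that something is new, unique, unknown or untested is made for them only; others in the source may bear on it.

Compound 2 `COc1cc(-c2cc(/C=C/C(=O)c3ccc(N)cc3)[nH]n2)cc(OC)c1OC` gives 70% in a functional assay on MDA-MB-231 cells (Homo sapiens) for cytotoxicity, read by sulforhodamine B assay, with a stated time of 48 h, tested at 1 uM (on this read-out lower numbers stand for a stronger effect and higher numbers for a weaker effect at the one concentration tested), the lowest of the three numbers. Compound 1 `COc1ccc(-c2cc(/C=C/C(=O)c3ccc(N)cc3)[nH]n2)cc1` gives 78%, which lies within the scatter of compound 2. Compound 3 `COc1cc(-c2cc(/C=C/C(=O)c3ccc(Cl)c(Cl)c3)[nH]n2)cc(OC)c1OC` gives 89%; the step of a number 19 percentage points higher from compound 2 to compound 3 (beyond the scatter) is the only one beyond the scatter, and it concerns the aryl group on the carbonyl carbon, not the part changed here. Compound 4 `COc1ccc(-c2cc(/C=C/C(=O)c3ccc(N)cc3)[nH]n2)cc1OC` differs from compound 2 by hydrogen in place of methoxy on an aromatic carbon. Among the measured compounds shown here, no measured step removes a methoxy group, and the values of compound 1 and compound 2 sit within the scatter of each other, so no step beyond the scatter is expected in this assay. Compound 4 is therefore estimated at 74%, ranging from 60% to 88%. This would be an expected step of a number 4 percentage points higher from compound 2 to compound 4 (within the scatter), within the scatter.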

Compound 4, a percentage reported as activity, at one concentration (the size of the read-out at that concentration, not a potency): 98%
Compound 4: the middle estimate sits 24 percentage points below what was measured; the measured number lies above the stated range.
By their numbers in this assay, from the lowest: compounds 2 and 1 (each within the scatter of the next); then compounds 3 and 4 (each within the scatter of the next).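

In this assay, this position proved sensitive to methoxy substitution: removing the methoxy group gave a number 28 percentage points higher from compound 2 to compound 4 (beyond the scatter), while the change from the other side, methoxy in place of hydrogen, gave a number 20 percentage points higher from compound 1 to compound 4 (beyond the scatter). The number therefore does not move in one direction as methoxy groups are added, since compound 4 stands apart from both neighbours even though compound 1 and compound 2 lie within the scatter of each other. No available evidence accounts for this behaviour. The compounds shown leave open how a hydroxy group or a fluorine atom would behave at this position. They also leave open whether the same methoxy pattern holds with 3,4-dichlorophenyl on the carbonyl carbon.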